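Swapping a Pyrrolidine Amide for a Plain Azepane Ring

The compounds below may be only part of what the source reports. "The series", "measured", "known", "first", "only" and "open" are said of these compounds alone.

Of the compounds shown here, three built on one shared core have been tested in an assay on isolated protein for displacement of a labelled ligand from melanin-concentrating hormone receptor 1 (Homo sapiens); a lower number here means a stronger inhibitor, a higher number a weaker inhibitor. Compound 1 `CC1CCCN1c1ccc2cc(NC(=O)CCc3ccc(C(F)(F)F)cc3)ccc2n1` gives 5 nM. Compound 2 `O=C(CCc1ccc(C(F)(F)F)cc1)Nc1ccc2nc(N3CCC(c4ccccc4)C3)ccc2c1` gives 25 nM. Compound 3 `CC(C)C(=O)NC1CCN(c2ccc3cc(NC(=O)CCc4ccc(C(F)(F)F)cc4)ccc3n2)C1` gives 1 nM, the lowest of the three numbers, with compound 1 nearest and compound 2 furthest. The steps among them are a 5.0-fold higher number from compound 1 to compound 2 (0.70 log units; beyond the scatter), a 5.0-fold lower number from compound 1 to compound 3 (0.70 log units; beyond the scatter) and a 25-fold lower number from compound 2 to compound 3 (1.40 log units; beyond the scatter). Compound 4 `O=C(CCc1ccc(C(F)(F)F)cc1)Nc1ccc2nc(N3CCCCCC3)ccc2c1` has not yet been measured; it differs from compound 3 by azepan-1-yl in place of 3-((isopropylcarbonyl)amino)pyrrolidin-1-yl on an aromatic carbon. All three measured steps bear on this change, since each alters the saturated ring on the same aromatic carbon. Like compound 4, compound 1 carries a ring without the amide group, and compound 1 gives 5 nM, so the number expected for compound 4 lies toward that of compound 1. For compound 4 the expected step in this assay is therefore a 10-fold higher number from compound 3 to compound 4 (1.00 log units; beyond the scatter). Compound 4 is estimated at 10 nM, within a range of 3 nM to 40 nM.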

Compound 4, half-maximal inhibitory concentration: 36 nM
Beside the measured number, compound 4's estimate is 3.6-fold (0.56 log units) below it; low and high end bracket the measured number.
By their numbers in this assay, from the lowest: compound 3; then compound 1; then compounds 2 and 4 (each within the scatter of the next).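

In this assay there is a 36-fold higher number from compound 3 to compound 4 (1.56 log units; beyond the scatter) when the plain azepan-1-yl ring replaces the 3-((isopropylcarbonyl)amino)pyrrolidin-1-yl group, so all three rings without an amide now sit at higher numbers than compound 3. These amide-free rings are not all alike: there is a 7.2-fold higher number from compound 1 to compound 4 (0.86 log units; beyond the scatter) for the change from 2-methylpyrrolidin-1-yl, while a 1.4-fold higher number from compound 2 to compound 4 (0.16 log units; within the scatter) leaves the azepan-1-yl and 3-phenylpyrrolidin-1-yl rings indistinguishable here. No measurement offers an explanation for these differences.

Still open, from the compounds shown here alone, is whether the gain belongs to the amide group itself or to the five-membered ring that carries it. A pyrrolidine ring bearing a plain amine or a carboxylic acid in place of the (isopropylcarbonyl)amino group, or an azepane ring carrying that same amide, would help separate the two.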